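Chloro for fluoro on the indole of a staurosporine-like core

The compounds below may be only part of what the source reports. "The series", "measured", "known", "first", "only" and "open" are said of these compounds alone.

Compound 1 `CO[C@@H]1[C@H](N(C)c2ncc(-c3c[nH]c4ccc(Cl)cc34)s2)C[C@H]2O[C@]1(C)n1c3ccccc3c3c4c(c5c6cc(Cl)ccc6n2c5c31)C(=O)NC4` gives > 10000 nM in a functional assay on K562 cells (Homo sapiens) for antiproliferative activity, read by CellTiter-Glo, with a stated time of 72 h; on this read-out higher numbers stand for weaker inhibition and lower numbers for stronger inhibition.
Compound 2 `CO[C@@H]1[C@H](N(C)c2ncc(-c3c[nH]c4ccc(F)cc34)s2)C[C@H]2O[C@]1(C)n1c3ccccc3c3c4c(c5c6cc(Br)ccc6n2c5c31)C(=O)NC4` gives > 10000 nM in this assay.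

Among the measured compounds shown here, both values are limits of the assay, not numbers, so compound 2 stands at the limit of > 10000 nM in this assay, at which 2 of the 2 values shown sit, with no measured step to follow. Compound 3 `CO[C@@H]1[C@H](N(C)c2ncc(-c3c[nH]c4ccc(Cl)cc34)s2)C[C@H]2O[C@]1(C)n1c3ccccc3c3c4c(c5c6cc(Br)ccc6n2c5c31)C(=O)NC4` differs from compound 2 by chloro in place of fluoro on an aromatic carbon. With every neighbour at a limit, no direction beyond the scatter can be expected; compound 3 is estimated at 15000 nM, between 5000 nM and 50000 nM, most likely again reported as a limit, which is the step that the limit leaves unreadable from compound 2 to compound 3 expected.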

Compound 3, half-maximal inhibitory concentration: > 10000 nM
Compound 3 gave a limit, no number; the forecaster's own chance of this, stated with the estimate: 80%; the middle value does not contradict the limit.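

Among the compounds shown here, compound 3 also gives only a limit, so no step from compound 1 or compound 2 to compound 3 can be read: the limit of > 10000 nM in this assay, at which 3 of the 3 values shown sit. How these swaps change activity stays open, as no compound shown gives a number in this assay.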